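Sugar Acetylation and Acyl Chain Length in Thiadiazole Thioglycosides

The source may report more compounds than this note shows. Statements on the series, on what has been measured and on what is new or still open speak of the compounds shown alone.

Compound 1 `CCCCCCCC/C=C\CCCCCCCC(=O)Nc1nnc(S[C@@H]2O[C@H](COC(C)=O)[C@H](OC(C)=O)[C@H](OC(C)=O)[C@H]2OC(C)=O)s1` gives 23600 nM in a functional assay on MDA-MB-231 cells (Homo sapiens) for cytotoxicity, read by MTT assay, with a stated time of 24 h; a lower number here means a stronger inhibitor, a higher number a weaker inhibitor. Compound 2 `CCCCCCCC/C=C\CCCCCCCC(=O)Nc1nnc(S[C@@H]2O[C@H](CO)[C@H](O)[C@H](O)[C@H]2O)s1` gives 43600 nM in this assay, and compound 3 `CCCCCC(=O)Nc1nnc(S[C@@H]2O[C@H](CO)[C@H](O)[C@H](O)[C@H]2O)s1` gives 28700 nM. The difference between the core of compound 1 and the core of compound 2 is not broken down here. From compound 2 to compound 3 the change is hydrogen in place of dodec-3-en-1-yl on a saturated chain carbon, five bonds along the chain from a carbonyl carbon, and that step is a 1.5-fold lower number from compound 2 to compound 3 (0.18 log units; within the scatter). Compound 4 `CCCCCC(=O)Nc1nnc(S[C@@H]2O[C@H](COC(C)=O)[C@H](OC(C)=O)[C@H](OC(C)=O)[C@H]2OC(C)=O)s1` stands to compound 1 as compound 3 stands to compound 2: the change is hydrogen in place of dodec-3-en-1-yl on a saturated chain carbon, five bonds along the chain from a carbonyl carbon, the same change at the same place. A step of a 1.3-fold lower number from compound 1 to compound 4 (0.12 log units; within the scatter) is expected, because the earlier step of a 1.5-fold lower number from compound 2 to compound 3 (0.18 log units; within the scatter) stayed within the scatter. Compound 4 is accordingly estimated at 18000 nM in this assay, with a likely range from 9000 nM to 40000 nM.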

Compound 4, half-maximal inhibitory concentration: 25400 nM
The estimate for compound 4 lay 1.4-fold (0.15 log units) below the measured number, within the range that was stated.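

In this assay, hydrogen in place of dodec-3-en-1-yl gives a 1.1-fold higher number from compound 1 to compound 4 (0.03 log units; within the scatter). Set beside the same change on the core of compound 2, this step does not differ from the earlier one: the same change on two cores in this assay, a 1.5-fold lower number (0.18 log units; within the scatter) from compound 2 to compound 3 and a 1.1-fold higher number (0.03 log units; within the scatter) from compound 1 to compound 4, 1.6-fold (0.21 log units) apart, within the scatter of two such steps. This shows that the change carried across these two cores without a detectable difference, but both steps lie within the scatter, so it does not show that a real effect of a fixed size transfers, and two cores cannot establish a rule for the series.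

The compounds shown leave open whether an amine, a carboxylic acid or a saturated chain in place of dodec-3-en-1-yl would give a step beyond the scatter.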